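The source may hold more compounds than are shown below. What is called first, only, known or untested is meant among the compounds shown, and "the series" means these compounds.

Compound 1 `O=C(N/N=C/c1ccccc1)c1ccc(-c2nc3ccccc3s2)cc1` gives in an assay on isolated protein for inhibition of Maltase-glucoamylase (Homo sapiens), with a stated time of 15 min (on this read-out higher numbers stand for weaker inhibition and lower numbers for stronger inhibition), a value of 8050 nM. Compound 2 `O=C(N/N=C/c1ccc(F)c(Br)c1)c1ccc(-c2nc3ccccc3s2)cc1` gives 28000 nM, and compound 3 `O=C(N/N=C/c1cccc(O)c1)c1ccc(-c2nc3ccccc3s2)cc1` gives 9210 nM. Among these three numbers compound 3 stands second highest: its nearest neighbour is compound 1, and the step of a 1.1-fold higher number from compound 1 to compound 3 (0.06 log units; within the scatter) lies within the scatter, so the two cannot be ordered; the furthest is compound 2, reached by the step of a 3.0-fold lower number from compound 2 to compound 3 (0.48 log units; beyond the scatter), which is beyond the scatter. The remaining step, a 3.5-fold higher number from compound 1 to compound 2 (0.54 log units; beyond the scatter), is also beyond the scatter.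

Compound 4 `O=C(N/N=C/c1cc(O)ccc1O)c1ccc(-c2nc3ccccc3s2)cc1` is not yet measured. It differs from compound 3 by hydroxy in place of hydrogen on an aromatic carbon, the added group sitting ortho to a large group and para to a hydroxy group, so that the 3-hydroxyphenyl becomes a 2,5-dihydroxyphenyl. Among the compounds with values here, the one measured step of the same kind, hydroxy in place of hydrogen on an aromatic carbon, is a 1.1-fold higher number from compound 1 to compound 3 (0.06 log units; within the scatter), which stayed within the scatter; the steps involving compound 2 change halogens and do not bear directly on this. On that basis the step of a 1.0-fold lower number from compound 3 to compound 4 (0.01 log units; within the scatter) is expected to remain within the scatter. Compound 4 is therefore estimated at 9000 nM, within a range from 4000 nM to 22000 nM.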

Compound 4, half-maximal inhibitory concentration: 11900 nM
Beside the measured number, compound 4's estimate is 1.3-fold (0.12 log units) below it, and the stated range covers the measured number.
By their numbers in this assay, from the lowest: compounds 1, 3 and 4 (each within the scatter of the next); then compound 2.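

In this assay, the second hydroxy, which turns the 3-hydroxyphenyl into a 2,5-dihydroxyphenyl, gives the step of a 1.3-fold higher number from compound 3 to compound 4 (0.11 log units; within the scatter), so hydroxy in place of hydrogen at this place, ortho to a large group and para to a hydroxy group, stays within the scatter, and the comparison with the plain phenyl, a 1.5-fold higher number from compound 1 to compound 4 (0.17 log units; within the scatter), does so as well, even with both hydroxy groups present. Compounds 1, 3 and 4 therefore cannot be ordered, while the step of a 2.4-fold lower number from compound 2 to compound 4 (0.37 log units; beyond the scatter) shows that the 2,5-dihydroxyphenyl, like the phenyl and the 3-hydroxyphenyl, stands apart from the 3-bromo-4-fluorophenyl of compound 2. Nothing measured alongside these numbers accounts for what they show.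

From the compounds shown here alone, it remains open whether a methoxy or an amine at this same place would also stay within the scatter, or whether a larger step would appear. The compounds shown also leave unresolved how the step involving compound 2 divides between its bromo and its fluoro substituents, as the two appear only together.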